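Swapping a Dimethylphenyl for a Nitrophenyl in Compound 1

This account rests on a few compounds, and the source may have more. Where it says the series, first, only, none or still open, it means among the compounds named here.

The compounds were tested in a functional assay on HeLa cells (Homo sapiens) for cytotoxicity, read by WST assay, with a stated time of 48 h; a higher number here means a weaker inhibitor, a lower number a stronger inhibitor. Compound 1 `Cc1ccc(/C=C/C[C@H]2C[C@@H]([C@@H](O)c3ccccc3)CO[C@@H]2c2ccccc2)cc1C` gives 10000 nM, the lowest of the two numbers recorded here. Compound 3 `COc1ccc(/C=C/C[C@H]2C[C@H]([C@H](O)c3ccc(OC)c(OC)c3)CO[C@@H]2c2ccc(OC)c(OC)c2)cc1OC` gives 34600 nM, a gap from compound 1 that lies beyond the usual scatter. Compound 2 `COc1ccc(/C=C/C[C@H]2C[C@@H]([C@@H](OC(C)=O)c3ccc(OC)c(OC)c3)CO[C@@H]2c2ccc(OC)c(OC)c2)cc1OC` reaches only the limit of the assay, > 100000 nM, which is not a number. Compound 4 `O=[N+]([O-])c1ccc(/C=C/C[C@H]2C[C@@H]([C@@H](O)c3ccccc3)CO[C@@H]2c2ccccc2)cc1` differs from compound 1 by 4-nitrophenyl in place of 3,4-dimethylphenyl on a double-bonded chain carbon bound to a double-bonded chain carbon. Among the measured compounds shown here, no measured pair isolates this change, so in this assay only a modest shift is expected, its direction uncertain and possibly within the scatter. Compound 4 is therefore estimated at 15000 nM, between 4000 nM and 60000 nM. The expected step of a 1.5-fold higher number from compound 1 to compound 4 (0.18 log units; within the scatter) is a small one.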

Compound 4, half-maximal inhibitory concentration: 12400 nM
Estimate against measurement, compound 4: 1.2-fold (0.08 log units) above; low and high end bracket the measured number.
By their numbers in this assay, from the lowest: compounds 1 and 4 (each within the scatter of the next); then compound 3. At a limit, above all of these: compound 2.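

In this assay, exchanging 3,4-dimethylphenyl for 4-nitrophenyl on a double-bonded chain carbon bound to a double-bonded chain carbon gives a 1.2-fold higher number from compound 1 to compound 4 (0.09 log units; within the scatter) and so leaves the two compounds level. Among the compounds shown here, this is the first exchange at a single place on the shared core, and the earlier compounds, which differ in several places, could not show it. Nothing measured here explains this result.

As far as these compounds go, whether an aryl ring carrying an amine or a carboxylic acid would read the same remains open. A single exchange also establishes no trend at this position.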